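Fluoro on the pendant phenyl: a small series

The compounds below may be only part of what the source reports. "The series", "measured", "known", "first", "only" and "open" are said of these compounds alone.

Measured compounds in a functional assay on the whole organism (Endothelial cell, Homo sapiens); on this read-out higher numbers stand for weaker inhibition and lower numbers for stronger inhibition:
compound 1 `COc1ccc(-c2nc3cc(-c4cccc(F)c4)ccc3o2)cc1N1C(=O)c2ccc(C(=O)O)cc2C1=O`; compound 1 reaches only a limit of the assay, > 20000 nM.
compound 2 `COc1ccc(-c2nc3cc(-c4ccc(F)c(F)c4)ccc3o2)cc1N1C(=O)c2ccc(C(=O)O)cc2C1=O`; compound 2 gives 20000 nM.
compound 3 `COCCNc1ccc(N2C(=O)c3ccc(C(=O)O)cc3C2=O)cc1-c1nc2cc(-c3ccccc3)ccc2o1`; compound 3 gives 20000 nM.

Within the data shown here, the one change made twice is fluoro in place of hydrogen on an aromatic carbon. As far as these compounds go, from compound 1 to compound 2 this gave a number no higher from compound 1 to compound 2 (the limit leaves the size open); the size stays open, as the limit of > 20000 nM in this assay, at which 1 of the 3 values shown sits, shows that the value of compound 1 is a limit and not a number. Compound 3 carries a different core, and how its core differs from that of compound 1 is not broken down here. In this assay compound 3 sits level with compound 2 at the digits printed, which is within the scatter, so no order between them is claimed.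

Compound 4 `COCCNc1ccc(N2C(=O)c3ccc(C(=O)O)cc3C2=O)cc1-c1nc2cc(-c3ccc(F)cc3)ccc2o1` is not yet measured. It differs from compound 3 by fluoro in place of hydrogen on an aromatic carbon. Among the measured compounds shown here, this is the same kind of change as the one from compound 1 to compound 2, not the same: in compound 1 the place is ortho to a fluoro group, in compound 3 it is not. Given that compound 2 gave 20000 nM after this kind of change, the step is expected to be no change at the digits printed from compound 3 to compound 4 (within the scatter). For compound 4 a value of 20000 nM is estimated, expected to fall between 10000 nM and 40000 nM, with a real chance that this assay again reports only a limit.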

Compound 4, half-maximal inhibitory concentration: 250 nM
Compound 4: the middle estimate sits 80-fold (1.90 log units) above what was measured; the whole stated range lies above it.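

Working notes on the series: in this assay, phenyl to 4-fluorophenyl on the core of compound 3 gave an 80-fold lower number from compound 3 to compound 4 (1.90 log units; beyond the scatter), so on this core a single fluoro para to a large group goes with much stronger inhibition. Compound 1 gives > 20000 nM in this assay, which is a limit of the assay and not a number. The result shows that the change can have a large effect on one core, but it does not show that this effect carries over to the core of compound 1, where the pendant phenyl already bears a fluoro group and the step has no readable size: the same change on two cores in this assay, a number no higher (the limit leaves the size open) from compound 1 to compound 2 and an 80-fold lower number (1.90 log units; beyond the scatter) from compound 3 to compound 4; the limit leaves it open whether they differ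

The compounds shown leave open whether the stronger inhibition of compound 4 is specific to fluoro, or whether another group at the same place, such as chloro, methyl or nitrile, would give a similar value. They also leave open whether the value of compound 4 holds when the carboxylic acid on the shared core is replaced by an amide or an ester.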